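Swapping the aryl group for a small ring

The source may hold more compounds than are shown below. What is called first, only, known or untested is meant among the compounds shown, and "the series" means these compounds.

Compound 2 `COc1ccc(C2CC(Nc3nc4ccc([N+](=O)[O-])cc4s3)=NN2C(C)=O)cc1O` and compound 1 `COc1ccc(C2CC(Nc3nc4ccc(Cl)cc4s3)=NN2C(C)=O)cc1O` share a core and differ only where a nitro replaces a chloro on an aromatic carbon. In a functional assay on the whole organism (Hindlimb, strain albino) with Mus musculus as the target, in the maximal electroshock model, with a stated time of 0.5 h (a lower number here means that less compound is needed, a higher number that more compound is needed for the effect), compound 1 gives 127 umol/kg, and compound 2 gives 178 umol/kg. The step of a 1.4-fold higher number from compound 1 to compound 2 (0.15 log units; within the scatter) is therefore within the scatter, and compound 2 stands as the higher of the two numbers without being separated from compound 1 beyond the scatter.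

Compound 3 `CC(=O)N1N=C(Nc2nc3ccc([N+](=O)[O-])cc3s2)CC1OC1=CC=C1` is not yet measured. It differs from compound 2 by a group of 5 heavy atoms (4 carbon, 1 oxygen; one four-membered non-aromatic ring of carbon only) in place of a group of 9 heavy atoms (7 carbon, 2 oxygen; one six-membered aromatic ring of carbon only), on a saturated ring carbon. Going by the values given here, this change sits on the saturated ring carbon of the core, far from the aromatic carbon where the only measured step took place. That step, from compound 1 to compound 2, was within the scatter and concerns a different part of the molecule, so it gives no direct guidance on the present change.

With nothing to anchor a direction, compound 3 is expected to land near compound 2, the estimated step being a 1.1-fold higher number from compound 2 to compound 3 (0.05 log units; within the scatter). In this assay compound 3 is therefore estimated at 200 umol/kg, within a wide range from 90 umol/kg to 450 umol/kg.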

Compound 3, dose for half-maximal effect: 274 umol/kg
Compound 3: middle estimate off by 1.4-fold (0.14 log units), on the low side, within the range that was stated.
By their numbers in this assay, from the lowest: compounds 1, 2 and 3 (each within the scatter of the next, the first and the last beyond it).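

Going by these compounds alone, this is the first view of the saturated ring carbon that carries the 3-hydroxy-4-methoxyphenyl group, since the earlier step concerned only a nitro and a chloro on an aromatic carbon. In this assay, exchanging that group of 9 heavy atoms for one of 5 heavy atoms, built on a four-membered non-aromatic ring, gives a 1.5-fold higher number from compound 2 to compound 3 (0.19 log units; within the scatter), so even a change this large in size and ring type does not separate the two compounds beyond the scatter. The exchange also takes the count of hydrogen-bond donors in the group from one to none, so in this pair neither the six-membered aromatic ring nor that donor proves necessary for the effect in this whole-animal test, and nothing available explains the result.

This single step cannot show how much the aromatic ring and the hydroxyl group each contribute, nor whether the same exchange would behave alike with chloro in place of nitro. It also leaves open what a simple methyl group, an amine, a carboxylic acid or a longer alkyl chain would do on this ring carbon.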